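The source may report more compounds than this note shows. Statements on the series, on what has been measured and on what is new or still open speak of the compounds shown alone.

The series shares one core, seen in compound 1 `Nc1scc(CN2CCN(c3ccc(Cl)cc3F)CC2)c1C(=O)c1ccc(Cl)cc1`, which in an assay on CHO cells for displacement of a labelled ligand from adenosine receptor A1 (Homo sapiens), read by scintillation counting, with a stated time of 120 min, tested at 10 uM (a higher number here means more inhibition at the concentration tested (going by the name of the read-out), a lower number less inhibition), gives 0%. Compound 2 `Nc1scc(CN2CCN(c3ccc(F)c(Cl)c3)CC2)c1C(=O)c1ccc(Cl)cc1` differs from it only in the aryl group on the piperazine nitrogen, and in this assay compound 2 gives 0%. Among the compounds with values here, the one measured step, no change at the digits printed from compound 1 to compound 2 (within the scatter), shows that exchanging one substituted phenyl for another left the read-out at the bottom of the scale, so compound 2 stands level with compound 1 and no compound in the set shows any inhibition at the tested concentration.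

Compound 3 `Nc1scc(CN2CCN(c3cccc(Cl)c3)CC2)c1C(=O)c1ccc(Cl)cc1` is the next step from compound 2. The change is hydrogen in place of fluoro on an aromatic carbon. Within the data shown here, no measured step removes a fluoro group, so the only guidance is the step from compound 1 to compound 2, which was no change within the scatter, and nothing in the data suggests that the shared core contributes any measurable inhibition. The step of no change at the digits printed from compound 2 to compound 3 (within the scatter) is therefore expected to be no change beyond the scatter. For compound 3 the value in this assay is estimated at 0%, with a range from -8% to 10%.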

Compound 3, a percentage reported as inhibition, at one concentration (the size of the read-out at that concentration, not a potency): 0%
Beside the measured number, compound 3's estimate shows no gap at the digits printed, within the range that was stated.
By their numbers in this assay, from the lowest: compounds 1, 2 and 3 (each within the scatter of the next).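

In this assay the step of no change at the digits printed from compound 2 to compound 3 (within the scatter) shows that removing the fluoro group from this aromatic carbon, ortho to a chloro group and para to a large group, leaves the read-out unmoved, something the earlier pair could not show, as its step exchanged one substituted phenyl for another. The step of no change at the digits printed from compound 1 to compound 3 (within the scatter) adds that 3-chlorophenyl, which carries no fluoro group, reads the same as 4-chloro-2-fluorophenyl, so among these three compounds a fluoro group on this ring makes no visible difference at the tested concentration. Nothing available here offers an explanation for this result.

All three compounds sit at the bottom of the scale, so the compounds shown leave open whether this exchange of fluoro for hydrogen would matter in a compound that shows some inhibition. They also leave open whether a larger change at this carbon, such as a methoxy group, an amine or a carboxylic acid in place of the fluoro group, would lift the read-out at all.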